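Chloroacetamide versus chloropyridine amides on the benzothiazole anilide core

This account rests on a few compounds, and the source may have more. Where it says the series, first, only, none or still open, it means among the compounds named here.

Measured so far:
- compound 1 `O=C(Nc1ccc(Cl)cc1)c1cc([N+](=O)[O-])ccc1Cl`: > 25000 nM (a limit)
- compound 2 `O=C(CCl)Nc1cccc(-c2nc3ccccc3s2)c1`: 1700 nM
- compound 3 `O=C(Nc1cccc(-c2nc3ccccc3s2)c1)c1ccc(Cl)nc1Cl`: > 25000 nM (a limit)

Within the data shown here, in an ADME assay on Raji cells (Homo sapiens) for inhibition, with a stated time of 72 h (a higher number here means that more compound is needed for the effect, a lower number that less compound is needed), compound 2 gives 1700 nM, the only actual number in the set. Compound 1 reaches only a limit, > 25000 nM. Compound 3 likewise stops at a limit, > 25000 nM. Among the measured compounds shown here, the step of an at least 14-fold higher number from compound 2 to compound 3 (1.16 log units; beyond the scatter) is therefore the one measured change that bears on the next compound.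

Compound 4 `O=C(Nc1cccc(-c2nc3ccccc3s2)c1)c1ccnc(Cl)c1` is not yet measured. It differs from compound 2 as follows: 2-chloropyridin-4-yl in place of chloromethyl on a carbonyl carbon. For the measured compounds named here, the change closely resembles the one from compound 2 to compound 3, where the number rose an at least 14-fold higher number from compound 2 to compound 3 (1.16 log units; beyond the scatter). A step of similar size and direction is expected here, an 18-fold higher number from compound 2 to compound 4 (1.25 log units; beyond the scatter), because the limit of > 25000 nM in this assay, at which 2 of the 3 values shown sit, marks where most of the series already sits. For compound 4 the expected value in this assay is 30000 nM, with a range from 8000 nM to 100000 nM, and a limit rather than a number is the likelier outcome.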

Compound 4, half-maximal effective concentration: > 25000 nM
Compound 4 ended at the assay's limit; the forecaster's own chance of this, stated with the estimate: 70%; the middle value is on the limit's open side.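

In this assay, a second chloropyridine amide, bearing 2-chloropyridin-4-yl on the carbonyl carbon in place of chloromethyl, gives the same kind of outcome as the 2,6-dichloropyridin-3-yl amide, so the loss is not confined to that one pyridine: the step is an at least 14-fold higher number from compound 2 to compound 4 (1.16 log units; beyond the scatter). The step between compound 3 and compound 4 cannot be read, as both values are limits. Among these compounds, compound 2 remains the only compound with an actual number, and the series now gathers at a single limit: the limit of > 25000 nM in this assay, at which 3 of the 4 values shown sit.

As far as these compounds go, how far compound 3 and compound 4 lie past that limit, and hence any order between the two pyridines, stays open. Also open, from the compounds shown here alone, is whether the number of compound 2 depends on the chlorine of its chloromethyl group; a plain methyl or an aminomethyl group on the same carbonyl carbon would bear on this.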